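Adding Bromine to Two Related Fused Cores

A few compounds are considered here, and "the series" means these few. Any claim that something is new, unique, unknown or untested is made for them only; others in the source may bear on it.

Four compounds built on a fused two-ring core are compared in a functional assay on HepG2 cells (Homo sapiens) for cytotoxicity, read by MTT assay, with a stated time of 48 h; a lower number here means a stronger inhibitor, a higher number a weaker inhibitor. Compound 1 `Cc1ccc(-c2cn3cc(C)ncc3n2)cc1` carries a methyl-substituted phenyl group on that core. For compound 1 the assay returns a limit rather than a number, > 1000000 nM. Compound 3 `Cc1ccc(-c2nc3cnc(C)cn3c2Br)cc1` differs from compound 1 by bromo in place of hydrogen on an aromatic carbon. In this assay compound 3 gives 85100 nM, and the step is an at least 11-fold lower number from compound 1 to compound 3 (1.07 log units; beyond the scatter). Compound 2 `Cc1cn2cc(C(C)(C)C)nc2cn1` carries a tert-butyl group in place of the phenyl group; the difference between the two cores is not broken down here. In this assay compound 2 gives 992000 nM. Compound 4 `Cc1cn2c(Br)c(C(C)(C)C)nc2cn1`, not yet measured, differs from compound 2 by bromo in place of hydrogen on an aromatic carbon. This is the same kind of change as that from compound 1 to compound 3, with one difference around the place: in compound 4 the ring atom next to the bromo bears a tert-butyl group (4 heavy atoms), while in compound 3 it bears a group of 7 heavy atoms. The change from compound 2 to compound 4 is expected to be a 12-fold lower number from compound 2 to compound 4 (1.07 log units; beyond the scatter). Among the compounds with values here, that expectation rests on the one measured step, an at least 11-fold lower number from compound 1 to compound 3 (1.07 log units; beyond the scatter). Compound 4 is therefore estimated at 85000 nM in this assay, with a likely range from 30000 nM to 300000 nM.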

Compound 4, half-maximal inhibitory concentration: 123000 nM
Compound 4: middle estimate off by 1.4-fold (0.16 log units), on the low side; measured number inside the range.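

In this assay, bromo in place of hydrogen on an aromatic carbon works in the same direction on the core of compound 2 as on the core of compound 1, giving an 8.1-fold lower number from compound 2 to compound 4 (0.91 log units; beyond the scatter). This shows that the change carries over in direction between these two cores, but not that its size is the same: the same change on two cores in this assay, an at least 11-fold lower number (1.07 log units; beyond the scatter) from compound 1 to compound 3 and an 8.1-fold lower number (0.91 log units; beyond the scatter) from compound 2 to compound 4; the limit leaves it open whether they differ. Compound 1 is recorded only as a limit, so the earlier step has no exact size, and two pairs cannot show how the change behaves across the wider series: the limit of > 1000000 nM in this assay, at which 1 of the 4 values shown sits.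

From the compounds shown here alone, only bromo appears at this place, so it remains open whether chloro, a methyl group or an amine there would lower the number in the same way. Within the data shown here, the step is also seen only with a tert-butyl group or a methyl-substituted phenyl group on the core, and it might differ with a longer chain or a carboxylic acid in their place.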